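The source may report more compounds than this note shows. Statements on the series, on what has been measured and on what is new or still open speak of the compounds shown alone.

Working notes on the series. Compound 1, `C/C1=C/C=C/C(=O)N[C@@H](C=O)C/C(C)=C/COCC/C=C/C(=O)C1`, gives 8480 nM in a functional assay on DU-145 cells (Homo sapiens) for antiproliferative activity, read by WST assay, with a stated time of 3 days; a higher number here means a weaker inhibitor, a lower number a stronger inhibitor. Compound 2, `COc1ccc(COC[C@H]2C/C(C)=C/COCC/C=C/C(=O)C/C(C)=C\C=C\C(=O)N2)cc1`, gives 4870 nM in this assay; the two differ only in that ((4-methoxybenzyl)oxy)methyl stands in place of formyl on a saturated ring carbon, and the step is a 1.7-fold lower number from compound 1 to compound 2 (0.24 log units; within the scatter). Within the data shown here, on the numbers so far compound 2 holds the lower of the two, but its distance from compound 1 lies within the scatter, so no order between them can be read.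

Compound 3, `C/C1=C/C=C/C(=O)N[C@@H](CO)C/C(C)=C/COCC/C=C/C(=O)C1`, is yet to be measured in this assay. Relative to compound 2 the change is hydrogen in place of 4-methoxybenzyl on an oxygen on a saturated carbon; cut one bond further out, it reads (4-methoxybenzyl)oxy to hydroxy, or ((4-methoxybenzyl)oxy)methyl to hydroxymethyl. Among the measured compounds shown here, the only measured step that touches this position is a 1.7-fold lower number from compound 1 to compound 2 (0.24 log units; within the scatter), which built up the same substituent from formyl and stayed within the scatter; no measured step removes the 4-methoxybenzyl from the oxygen. The expectation in this assay is therefore a change no larger than the scatter, in either direction. Compound 3 is estimated at 6000 nM, with a range from 2500 nM to 15000 nM. The expected step is a 1.2-fold higher number from compound 2 to compound 3 (0.09 log units; within the scatter).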

Compound 3, half-maximal inhibitory concentration: 11100 nM
The estimate for compound 3 lay 1.9-fold (0.27 log units) below the measured number, and the stated range covers the measured number.
By their numbers in this assay, from the lowest: compounds 2, 1 and 3 (each within the scatter of the next, the first and the last beyond it).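

Taking the 4-methoxybenzyl off the oxygen gives the first step at this position in this assay that lies beyond the scatter, though only modestly (a 2.3-fold higher number from compound 2 to compound 3 (0.36 log units; beyond the scatter)), whereas the step that built the same substituent from formyl did not separate its two compounds. Hydroxymethyl and formyl on the saturated ring carbon cannot be told apart (a 1.3-fold higher number from compound 1 to compound 3 (0.12 log units; within the scatter)), so among the three compounds only the pair carrying the ((4-methoxybenzyl)oxy)methyl and the hydroxymethyl groups differs by more than the scatter, and that difference is small. No evidence is at hand that would explain this step.

The compounds shown do not say whether the step follows the aromatic ring of the 4-methoxybenzyl group, its methoxy, or simply the capping of the oxygen; a plain benzyl ether and a methyl ether at the same oxygen would separate these readings. Going by these compounds, it also remains open how an amine or a carboxylic acid in place of the hydroxy would read in this assay, and whether any group here moves the number further than this modest step.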